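Swapping isopropyl for cyclopropyl on a kinase inhibitor

This account rests on a few compounds, and the source may have more. Where it says the series, first, only, none or still open, it means among the compounds named here.

Measured so far:
compound 1, `CC(C)n1cc(Nc2ncc(C3CC3)c(NCCCNC(=O)C3CCC3)n2)cn1`, 4 nM
compound 2, `Cc1nn(C)c2cc(Nc3ncc(C4CC4)c(NCCCNC(=O)C4CCC4)n3)ccc12`, 7 nM

Both compounds were tested in an assay on isolated protein for inhibition of serine/threonine-protein kinase TBK1 (Homo sapiens); a higher number here means a weaker inhibitor, a lower number a stronger inhibitor. Compound 1 shows the lower of the two numbers, but the gap to compound 2 lies within the usual scatter of repeated measurements, so the two cannot be told apart on these data. Within the data shown here, no pair of measured compounds differing in a single place is available, so there is no measured step to lean on.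

Compound 3, `O=C(NCCCNc1nc(Nc2cnn(C3CC3)c2)ncc1C1CC1)C1CCC1`, has not yet been measured. It differs from compound 1 in one place: cyclopropyl in place of isopropyl on an aromatic nitrogen. The isopropyl leaves and a cyclopropyl enters, both of three carbon atoms, at the aromatic nitrogen of the five-membered aromatic ring with 2 nitrogen.

Among the measured compounds shown here, since nothing among the measured compounds records what such an exchange does, the expectation is a change no larger than the scatter, the expected step being a 1.3-fold higher number from compound 1 to compound 3 (0.10 log units; within the scatter). Compound 3 is therefore estimated at 5 nM, with a range from 2 nM to 15 nM.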

Compound 3, half-maximal inhibitory concentration: 10 nM
Compound 3: the middle estimate sits 2.0-fold (0.30 log units) below what was measured; low and high end bracket the measured number.
By their numbers in this assay, from the lowest: compounds 1, 2 and 3 (each within the scatter of the next, the first and the last beyond it).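

In this assay, among these compounds, the exchange of isopropyl for cyclopropyl on the aromatic nitrogen gives a 2.5-fold higher number from compound 1 to compound 3 (0.40 log units; beyond the scatter) and so provides the first measured step, a modest weakening that goes beyond the scatter. It shows that this position responds even to a small change: both groups have 3 heavy atoms, all carbon, with no hydrogen-bond donors or acceptors and no net charge, and what the computed description separates them by is the three-membered ring of cyclopropyl. No measurement at hand says why the number rises.

This single pair cannot show whether the ring itself matters or whether any departure from isopropyl on this nitrogen would weaken the compound, and the same exchange on a different core also remains an open question. Ethyl, tert-butyl, cyclobutyl or a longer chain ending in an amine on the same nitrogen would show how far this position tolerates change and whether the step seen here belongs to a wider trend.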